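Carboxy for carbamoyl on a shared dihydropyridine-type scaffold? No: a single swap at the amide

The source may hold more compounds than are shown below. What is called first, only, known or untested is meant among the compounds shown, and "the series" means these compounds.

Measured so far:
- compound 1, `N#CC1=C(N)N(c2ccc(S(N)(=O)=O)cc2)C2=C(C(=O)CCC2)C1c1ccc(Cl)cc1Cl`: 40%
- compound 2, `N#CC1=C(NC(=O)c2ccccc2)N(c2ccc(S(N)(=O)=O)cc2)C2=C(C(=O)CCC2)C1c1ccc(Cl)cc1Cl`: 50%
- compound 3, `NC(=O)C1=C(N)N(c2ccc(S(N)(=O)=O)cc2)C2=C(C(=O)CCC2)C1c1ccc(Cl)cc1Cl`: 30%

All three compounds were tested in a functional assay on Ehrlich cells (Mus musculus) for cytotoxicity, read by trypan blue exclusion, with a stated time of 2 h, tested at 10 ug/mL; a higher number here means a stronger effect of the compound at the concentration tested, a lower number a weaker effect. Compound 3 gives the smallest of the three numbers, but the measured step of a number 10 percentage points lower from compound 1 to compound 3 (within the scatter) lies within the scatter, so the two cannot be told apart. Only compound 2 stands clearly apart from compound 3, with a number beyond the scatter. The other measured step, a number 10 percentage points higher from compound 1 to compound 2 (within the scatter), is likewise within the scatter.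

Compound 4, `NC1=C(C(=O)O)C(c2ccc(Cl)cc2Cl)C2=C(CCCC2=O)N1c1ccc(S(N)(=O)=O)cc1`, differs from compound 3 in one place: hydroxy in place of amino on a carbonyl carbon. Within the data shown here, no measured pair shows this exact exchange. Among the measured compounds shown here, the closest precedent is the change at the same carbonyl position from compound 1 to compound 3, a number 10 percentage points lower from compound 1 to compound 3 (within the scatter), and the change on the amine nitrogen, a number 10 percentage points higher from compound 1 to compound 2 (within the scatter); both left the read-out within the scatter. On that basis no shift beyond the scatter is expected for compound 4 in this assay. The expected step is no change at the digits printed from compound 3 to compound 4 (within the scatter), a change that would not be distinguishable from repeat measurement. Compound 4 is therefore estimated at 30%, with a range from 15% to 45%.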

Compound 4, a percentage reported as activity, at one concentration (the size of the read-out at that concentration, not a potency): 0%
Estimate against measurement, compound 4: 30 percentage points above; the whole stated range lies above it.
By their numbers in this assay, from the lowest: compound 4; then compounds 3, 1 and 2 (each within the scatter of the next, the first and the last beyond it).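

In this assay, among these compounds, this carbonyl carbon proves sensitive to what is attached to it: hydroxy in place of amino gives a number 30 percentage points lower from compound 3 to compound 4 (beyond the scatter) and is the first single exchange at this place to go clearly past the scatter. Set against the nitrile, the carboxy group gives a number 40 percentage points lower from compound 1 to compound 4 (beyond the scatter), so among the three groups seen on this double-bonded ring carbon, nitrile and carbamoyl cannot be told apart, while carboxy stands apart from both and compound 4 shows 0% at the concentration tested. Nothing in the data bears on why exchanging one heavy atom, nitrogen for oxygen, has so large an effect.

The compounds shown leave open whether this loss belongs to the free carboxylic acid itself or would also appear with a methyl ester or a methyl amide on the same carbon. Also open, from the compounds shown here alone, is whether benzoyl on the amine nitrogen would change the read-out with carboxy in place, and whether a higher concentration would bring out any effect of compound 4.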